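This account rests on a few compounds, and the source may have more. Where it says the series, first, only, none or still open, it means among the compounds named here.

In a functional assay on HEK293 cells for agonist activity at Bombesin receptor subtype-3 (Homo sapiens), read by luminescence and calcium flux, with a stated time of 10 min (a lower number here means that less compound is needed, a higher number that more compound is needed for the effect), the three measured compounds give these numbers:

Compound 1, `CCC(C)(C)Cc1c[nH]c(CCc2ccc(-n3ccnn3)cc2)n1`, gives 93 nM.
Compound 2, `CCC(C)(C)Cc1c[nH]c(CCc2ccc(-c3cnccn3)cc2)n1`, gives 100 nM.
Compound 3, `c1ccc(-c2ccc(CCc3nc(CC4CCCC4)c[nH]3)cc2)nc1`, gives 98 nM.

On these numbers compound 2 stands at the highest of the three, though each of the other two lies within the usual scatter of it, so the three cannot be told apart.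

Compound 4, `CCC(C)(C)Cc1c[nH]c(CCc2ccc(-c3cnsc3)cc2)n1`, is compound 2 with one change: 1,2-thiazol-4-yl in place of pyrazin-2-yl on an aromatic carbon. Within the data shown here, one measured step bears on this kind of exchange. From compound 1 to compound 2 a five-membered aromatic ring on the same carbon was replaced by a six-membered one, and that step was a 1.1-fold higher number from compound 1 to compound 2 (0.03 log units; within the scatter), within the scatter. The change to compound 4 again swaps one small aromatic ring bearing two hetero atoms for another at the same place. On that basis, compound 4 is expected to show a step of no change at the digits printed from compound 2 to compound 4 (within the scatter), nothing beyond the scatter. The estimate for compound 4 in this assay is 100 nM, with a range from 45 nM to 220 nM.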

Compound 4, half-maximal effective concentration: 100 nM
Compound 4: the middle estimate sits on the measured number at the digits printed, and the stated range covers the measured number.
By their numbers in this assay, from the lowest: compounds 1, 3, 2 and 4 (each within the scatter of the next).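

In this assay, the step with 1,2-thiazol-4-yl in place of pyrazin-2-yl is no change at the digits printed from compound 2 to compound 4 (within the scatter), and the step with 1,2-thiazol-4-yl in place of 1H-1,2,3-triazol-1-yl is a 1.1-fold higher number from compound 1 to compound 4 (0.03 log units; within the scatter). Until now a single exchange at this place could be read; there are now three rings on this aromatic carbon, para to a large group, two five-membered and one six-membered, one of them carrying sulfur, and the numbers do not separate them. No supporting measurement is available to say why these rings cannot be told apart.

All three groups are small aromatic rings, so the compounds shown leave open how a group of another kind on this carbon would read, such as an amine, a carboxylic acid or a longer alkyl chain.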